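The compounds below may be only part of what the source reports. "The series", "measured", "known", "first", "only" and "open" are said of these compounds alone.

Compound 1, `Cc1ccccc1-n1nncc1CN1C(=O)C2(C(C#N)=C(N)Oc3c2c2nc4ccccc4nc2c2ccccc32)c2ccccc21`, in an ADME assay on HUVEC cells (Homo sapiens) for antiproliferative activity, read by MTT assay, with a stated time of 48 h (on this read-out higher numbers stand for weaker inhibition and lower numbers for stronger inhibition), gives > 50000 nM, which is a limit of the assay and not a number.
Compound 2, `N#CC1=C(N)Oc2c(c3nc4ccccc4nc3c3ccccc23)C12C(=O)N(Cc1cnnn1-c1ccc(F)cc1)c1ccccc12`, in this assay gives > 50000 nM, again a limit.
Compound 3, `N#CC1=C(N)Oc2c(c3nc4ccccc4nc3c3ccccc23)C12C(=O)N(Cc1cnnn1-c1ccc([N+](=O)[O-])cc1)c1ccccc12`, in this assay gives > 50000 nM, once more a limit.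

All three compounds share one core and differ only in the aryl group carried on an aromatic nitrogen of the five-membered aromatic ring with three nitrogens. Compound 3 therefore stands where every measured value stands: at the limit of > 50000 nM in this assay, at which 3 of the 3 values shown sit. Compound 4, `Cc1ccc(C)c(-n2nncc2CN2C(=O)C3(C(C#N)=C(N)Oc4c3c3nc5ccccc5nc3c3ccccc43)c3ccccc32)c1`, arises from compound 3 by 2,5-dimethylphenyl in place of 4-nitrophenyl on an aromatic nitrogen. The measured steps that touch this position are a step that the two limits leave unreadable from compound 1 to compound 2, a step that the two limits leave unreadable from compound 1 to compound 3 and a step that the two limits leave unreadable from compound 2 to compound 3; none of them is readable, since each end sits at the limit. Swapping one aryl group for another on this nitrogen has so far never pulled a value into the measurable range. Compound 4 is therefore expected to give 50000 nM, within 20000 nM to 100000 nM. Going by the values given here, the step of a number no higher from compound 3 to compound 4 (the limit leaves the size open) is expected to be, in effect, no step.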

Compound 4, half-maximal inhibitory concentration: > 50000 nM
Compound 4: a limit, no number (the forecaster's own chance of this, stated with the estimate: 85%); the middle value lies on the limit itself.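

No step from compound 1, compound 2 or compound 3 to compound 4 can be read, since all four results are limits and not numbers: the limit of > 50000 nM in this assay, at which 4 of the 4 values shown sit.

The compounds shown leave open whether any aryl group on this nitrogen can bring a value into the measurable range in this assay.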